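Chain length and antiproliferative activity in a furanose amine series

The compounds below may be only part of what the source reports. "The series", "measured", "known", "first", "only" and "open" are said of these compounds alone.

The measured compounds are: compound 1, `CCCCCCCCCCCCNC[C@@H]1OC[C@H](N)[C@@H]1O`, with 5870 nM; compound 2, `CCCCCCCNC[C@@H]1OC[C@H](N)[C@H]1O`; compound 3, `CCCCCCCCCCNC[C@@H]1OC[C@H](N)[C@H]1O`.

In a functional assay on A549 cells (Homo sapiens) for antiproliferative activity, read by MTT assay, with a stated time of 72 h (a higher number here means a weaker inhibitor, a lower number a stronger inhibitor), compound 1 gives 5870 nM. For compound 2 only a limit is reported, > 128000 nM. For compound 3 likewise only a limit is reported, > 128000 nM. The change from compound 3 to compound 2 is hydrogen in place of propyl on a saturated chain carbon, seven bonds along the chain from an amine nitrogen, and its step, a step that the two limits leave unreadable from compound 3 to compound 2, cannot be read, since both values are limits.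

Compound 4, `CCCCCCCCCNC[C@@H]1OC[C@H](N)[C@@H]1O`, is not yet measured. It differs from compound 1 by hydrogen in place of propyl on a saturated chain carbon, nine bonds along the chain from an amine nitrogen. This is the same kind of change as that from compound 3 to compound 2, but the place differs: seven bonds along the chain from an amine nitrogen there, nine bonds here. How the core of compound 1 differs from that of compound 3 is not broken down here.

Compound 2 and compound 3 both sit at the limit of > 128000 nM in this assay, at which 2 of the 3 values shown sit. Shortening the chain of compound 1 is therefore expected to weaken inhibition, resting on compound 1 at 5870 nM. Compound 4 is expected to give 30000 nM, between 8000 nM and 128000 nM. This estimate means an expected step of a 5.1-fold higher number from compound 1 to compound 4 (0.71 log units; beyond the scatter).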

Compound 4, half-maximal inhibitory concentration: 22100 nM
For compound 4 the middle estimate is 1.4-fold (0.13 log units) above the measured one; low and high end bracket the measured number.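

In this assay, the change from propyl to hydrogen on a saturated chain carbon, nine bonds along the chain from an amine nitrogen, gives a 3.8-fold higher number from compound 1 to compound 4 (0.58 log units; beyond the scatter), so on the core of compound 1 the shortened chain goes with weaker inhibition. The same kind of change on the core of compound 3, seven bonds along the chain from an amine nitrogen, cannot be read, because compound 3 and compound 2 both stand at a limit and not at a number: the limit of > 128000 nM in this assay, at which 2 of the 4 values shown sit. The step therefore describes one core only and does not show whether the change would carry to the other core, in size or in direction.

The compounds shown leave open whether a chain longer than that of compound 1 would lower the number further on the same core. They also leave open how a chain bearing a carboxylic acid or a second amine would behave in this assay.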